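Chloro for Fluoro on the Phenyl Ring of Compound 2

This account rests on a few compounds, and the source may have more. Where it says the series, first, only, none or still open, it means among the compounds named here.

Of the compounds shown here, two of one shared core have been measured in a functional assay on the whole organism (strain Swiss albino) for inhibition, with Mus musculus as the target, in the formalin test, with stated times of 5 min and 30 min, at a dose of 100 mg/kg by the intraperitoneal route; on this read-out higher numbers stand for more inhibition at the one dose given (going by the name of the read-out) and lower numbers for less inhibition. Compound 1 `Nn1c(CCc2ccc(O)cc2)nnc1SCC(=O)N1N=C(c2cccs2)CC1c1ccccc1` gives 66.6% in this assay. Compound 2 `Nn1c(CCc2ccc(O)cc2)nnc1SCC(=O)N1N=C(c2cccs2)CC1c1ccc(F)cc1` gives 73.7% in this assay. The single measured step, a number 7.1 percentage points higher from compound 1 to compound 2 (within the scatter), stays within the scatter, so compound 2 stands alongside compound 1 rather than apart from it on the numbers shown.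

Compound 3 `Nn1c(CCc2ccc(O)cc2)nnc1SCC(=O)N1N=C(c2cccs2)CC1c1ccc(Cl)cc1` differs from compound 2 by chloro in place of fluoro on an aromatic carbon. The step of a number 7.1 percentage points higher from compound 1 to compound 2 (within the scatter) is the one that bears on this change: it concerns the same aromatic carbon, and it was small. Among the compounds with values here, no measured step shows one halogen exchanged for another at that carbon, so there is nothing to point to a move in either direction. With only a step within the scatter to lean on, no shift beyond the scatter is expected in this assay. Compound 3 is therefore expected to give 74% in this assay, in a range from 60% to 86%. This amounts to an expected step of a number 0.3 percentage points higher from compound 2 to compound 3 (within the scatter).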

Compound 3, a percentage reported as inhibition, in the whole organism at one dose (the size of the read-out at that dose, not a potency): 68.7%
Estimate against measurement, compound 3: 5.3 percentage points above, within the range that was stated.
By their numbers in this assay, from the lowest: compounds 1, 3 and 2 (each within the scatter of the next).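

With chloro on this aromatic carbon, a halogen exchange at this position can now be read directly in this assay (a number 5 percentage points lower from compound 2 to compound 3 (within the scatter)), and so can chloro against the hydrogen of compound 1 (a number 2.1 percentage points higher from compound 1 to compound 3 (within the scatter)). Together with the earlier fluoro step (a number 7.1 percentage points higher from compound 1 to compound 2 (within the scatter)), this shows that hydrogen, fluoro and chloro on this carbon, para to a large group, are not told apart by this read-out at the one dose given: each of the three steps lies within the scatter, so the result gives no order among the three compounds and no sign that a halogen at this carbon matters. No measurement available here speaks to why these three compounds sit so close together, and nothing can be said about the origin of the small steps seen in this result.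

The compounds shown leave open whether a group of another kind on this carbon, such as an amine, a methoxy group or a carboxylic acid, would produce a step beyond the scatter. They also leave open whether compound 1, compound 2 and compound 3 would still sit together at doses other than the single one used here.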